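The source may report more compounds than this note shows. Statements on the series, on what has been measured and on what is new or still open speak of the compounds shown alone.

Measured so far:

compound 1, `Cc1ccc(/C=N/NC(N)=S)cc1`: 64%
compound 2, `CCc1ccc(/C=N/NC(N)=S)cc1`: > 100%, a limit of the assay rather than a number
compound 3, `Cc1ccccc1/C=N/NC(N)=S`: > 100%, likewise a limit of the assay

Of the compounds shown here, three have been tested in a functional assay on B16 cells (Mus musculus) for inhibition, tested at 10 uM; a higher number here means more inhibition at the concentration tested (going by the name of the read-out), a lower number less inhibition. Compound 1 reaches 64%. Compound 2 is reported at > 100%, which is a limit of the assay and not a number. Compound 3 is likewise reported at > 100%, again a limit. The change from compound 1 to compound 2 is methyl in place of hydrogen on a saturated chain carbon bound to an aromatic carbon, and it gives a number at least 36 percentage points higher from compound 1 to compound 2 (beyond the scatter). Two of the three values sit at the same limit, (the limit of > 100% in this assay, at which 2 of the 3 values shown sit), so the top of the measurable range is reached twice in this small set.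

Compound 4, `CCc1ccccc1/C=N/NC(N)=S`, has not yet been measured. It stands to compound 3 as compound 2 stands to compound 1: the change is methyl in place of hydrogen on a saturated chain carbon bound to an aromatic carbon, the same change at the same place. The difference between the core of compound 1 and the core of compound 3 is not broken down here.

For compound 4, an inhibition of 100% is expected, within a range from 85% to 100%. The step this estimate means, a number no higher from compound 3 to compound 4 (the limit leaves the size open), is expected to be small, because compound 3 already stands at > 100%. The expectation also draws on the earlier step of a number at least 36 percentage points higher from compound 1 to compound 2 (beyond the scatter), which went upward beyond the scatter, so a fall from compound 3 to compound 4 seems unlikely.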

Compound 4, a percentage reported as inhibition, at one concentration (the size of the read-out at that concentration, not a potency): > 100%
Compound 4: only a limit was reported; the forecaster's own chance of this, stated with the estimate: 75%; the middle value lies on the limit itself.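

In this assay, compound 4 gives > 100%, a limit of the assay and not a number. Among the compounds shown here, compound 3 is also reported only as a limit, so no step between compound 3 and compound 4 can be read. This limit now recurs across the set: the limit of > 100% in this assay, at which 3 of the 4 values shown sit. The compounds shown leave open how far compound 2, compound 3 and compound 4 differ from one another in inhibition.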